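The compounds below may be only part of what the source reports. "The series", "measured", "known", "first", "only" and "open" are said of these compounds alone.

Among the compounds with values here, compound 3 `NC(=O)[C@@H](c1ccccc1)N(C(=O)c1ccccc1)[C@@H]1CCc2ccc(Cl)cc21` stands second highest of the three numbers so far. In an assay on HEK293T cells for antagonist activity at transient receptor potential cation channel subfamily M member 8 (Homo sapiens), read by fluorescence and calcium flux, with a stated time of 60 min (a higher number here means a weaker inhibitor, a lower number a stronger inhibitor), compound 1 `NC(=O)[C@@H](c1ccccc1)N(C(=O)c1ccccc1)[C@@H]1CCc2ccccc21` gives 270 nM, compound 2 `NC(=O)[C@@H](c1ccccc1)N(C(=O)c1ccccc1)[C@@H]1CCc2ccc(F)cc21` gives 90 nM, and compound 3 gives 120 nM. The step of a 2.3-fold lower number from compound 1 to compound 3 (0.35 log units; beyond the scatter) is modest, as is a 3.0-fold lower number from compound 1 to compound 2 (0.48 log units; beyond the scatter), while a 1.3-fold higher number from compound 2 to compound 3 (0.12 log units; within the scatter) is within the scatter.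

Compound 4 `NC(=O)[C@@H](c1ccccc1)N(C(=O)c1ccccc1)[C@@H]1CCc2c(F)cc(Cl)cc21` differs from compound 3 by fluoro in place of hydrogen on an aromatic carbon. Within the data shown here, the only fluoro-for-hydrogen step measured, a 3.0-fold lower number from compound 1 to compound 2 (0.48 log units; beyond the scatter), sits at another position of the same core and was modest; no step at this new position exists. A modest lowering or no change beyond the scatter in this assay is therefore expected for compound 4. Compound 4 is estimated at 80 nM, with a range from 35 nM to 200 nM, corresponding to an expected step of a 1.5-fold lower number from compound 3 to compound 4 (0.18 log units; within the scatter).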

Compound 4, half-maximal inhibitory concentration: 300 nM
For compound 4 the middle estimate is 3.8-fold (0.57 log units) below the measured one; measured number outside the range, above it.
By their numbers in this assay, from the lowest: compounds 2 and 3 (each within the scatter of the next); then compounds 1 and 4 (each within the scatter of the next).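

Fluoro on an aromatic carbon ortho to a fused ring and meta to a chloro group weakens inhibition in this assay (a 2.5-fold higher number from compound 3 to compound 4 (0.40 log units; beyond the scatter)), so this position on the chloro core does not tolerate the change freely. Fluoro in place of hydrogen therefore has no single direction across the series: the same change on two cores in this assay, a 3.0-fold lower number (0.48 log units; beyond the scatter) from compound 1 to compound 2 and a 2.5-fold higher number (0.40 log units; beyond the scatter) from compound 3 to compound 4, 7.5-fold (0.88 log units) apart, beyond the scatter of two such steps.

The compounds shown do not separate the effect of this position from that of the chloro group in compound 3. On these data alone, how a methyl, a methoxy or an amine would read at this position also remains open.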